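Anilino-purine series: hydroxyphenyl replacing chlorophenyl

A few compounds are considered here, and "the series" means these few. Any claim that something is new, unique, unknown or untested is made for them only; others in the source may bear on it.

Measured so far:
compound 1 `CCCCCCn1cnc2c(Nc3ccc(O)cc3)nc(N[C@H]3CC[C@H](N)CC3)nc21` gives 3500 nM;
compound 2 `CC(C)CCn1cnc2c(NCc3cccc(Cl)c3)nc(N[C@H]3CC[C@H](N)CC3)nc21` gives 4700 nM;
compound 3 `CC(C)CCn1cnc2c(Nc3ccc(Cl)cc3)nc(N[C@H]3CC[C@H](N)CC3)nc21` gives 2700 nM.

In a functional assay on MCF7 cells (Homo sapiens) for inhibition, read by fluorescence, with a stated time of 72 h (on this read-out lower numbers stand for stronger inhibition of growth and higher numbers for weaker inhibition of growth), compound 3 shows the lowest number of the three, but its gap to compound 1 and the step of a 1.7-fold lower number from compound 2 to compound 3 (0.24 log units; within the scatter) both lie within the scatter, so no ordering among the three compounds can be drawn.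

Compound 4 `CC(C)CCn1cnc2c(Nc3cccc(O)c3)nc(N[C@H]3CC[C@H](N)CC3)nc21` has not been measured. Its difference from compound 3 is: 3-hydroxyphenyl in place of 4-chlorophenyl on a nitrogen on an aromatic ring. Going by the values given here, no measured step covers this exchange directly; compound 1 carries a hydroxyphenyl group but differs from compound 3 in a second place as well, so its value can only be read as a rough pointer, and it sits close to compound 3. Among the compounds with values here, the only measured step, from compound 2 to compound 3, concerns a different change and is itself within the scatter.

Compound 4 is therefore expected to stay within the scatter of compound 3, with a step of about a 1.3-fold higher number from compound 3 to compound 4 (0.11 log units; within the scatter) and an estimated value near 3500 nM (range 1500 nM to 8000 nM).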

Compound 4, concentration for 50% growth inhibition: 12600 nM
Compound 4: middle estimate off by 3.6-fold (0.56 log units), on the low side, and the stated range ends below it.
By their numbers in this assay, from the lowest: compounds 3, 1 and 2 (each within the scatter of the next); then compound 4.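

In this assay, going by these compounds alone, the position on a nitrogen on an aromatic ring proves sensitive to this exchange: 3-hydroxyphenyl in place of 4-chlorophenyl gives a 4.7-fold higher number from compound 3 to compound 4 (0.67 log units; beyond the scatter), the first step beyond the scatter. Against the 3-chlorobenzyl group the same hydroxylated ring gives a 2.7-fold higher number from compound 2 to compound 4 (0.43 log units; beyond the scatter), so compound 4 stands apart from both chlorinated compounds. No measurement at hand accounts for this.

Going by these compounds, whether the step follows the hydroxyl itself or its place on the ring stays open. A 3-chlorophenyl or 3-methoxyphenyl group on the core of compound 3 would separate the two.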